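A Hydroxy Group Replaces Methyl on the Side Chain

This account rests on a few compounds, and the source may have more. Where it says the series, first, only, none or still open, it means among the compounds named here.

In a functional assay on HL60/MX2 cells (Homo sapiens) for antiproliferative activity, read by MTT assay, with a stated time of 48 h (a lower number here means a stronger inhibitor, a higher number a weaker inhibitor), compound 3 `CCCn1c(N)c(-c2nc3ccccc3[nH]2)c2nc(C#N)c(C#N)nc21` is reported only as a limit, > 50000 nM. Compound 1 `CCn1c(N)c(-c2nc3ccccc3[nH]2)c2nc(C#N)c(C#N)nc21` also gives only a limit, > 50000 nM. Both compounds therefore stand at the limit of > 50000 nM in this assay, at which 2 of the 3 values shown sit. Compound 2 `CN(C)CCn1c(N)c(-c2nc3ccccc3[nH]2)c2nc(C#N)c(C#N)nc21` alone gives a measured number, 3780 nM.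

Compound 4 `N#Cc1nc2c(-c3nc4ccccc4[nH]3)c(N)n(CCO)c2nc1C#N` differs from compound 3 by hydroxy in place of methyl on a saturated chain carbon, two bonds along the chain from an aromatic nitrogen, with hydroxy in place of methyl on a saturated chain carbon, two bonds along the chain from an aromatic nitrogen. Three measured steps at this place bear on the change. Two are large and involve dimethylamino: an at least 13-fold lower number from compound 1 to compound 2 (1.12 log units; beyond the scatter) and an at least 13-fold higher number from compound 2 to compound 3 (1.12 log units; beyond the scatter). The third, a step that the two limits leave unreadable from compound 1 to compound 3, involves methyl and hydrogen. For the measured compounds named here, compound 4 carries no dimethylamino group, so the large steps offer no direct precedent, and hydroxy itself has not been tested. Compound 4 is therefore expected to remain close to the limit in this assay. The estimated change is an at least 1.2-fold lower number from compound 3 to compound 4 (0.09 log units; that floor lies within the scatter), and no step beyond the scatter is expected. The estimate for compound 4 is 40000 nM, with an expected range of 12000 nM to 80000 nM.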

Compound 4, half-maximal inhibitory concentration: > 50000 nM
Compound 4: no number, only a limit (the forecaster's own chance of this, stated with the estimate: 60%); middle value at least 1.2-fold (0.09 log units) from the limit.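

In this assay, hydroxy on a saturated chain carbon, two bonds along the chain from an aromatic nitrogen, leaves compound 4 at the same limit as the compounds with hydrogen or methyl at this place: the limit of > 50000 nM in this assay, at which 3 of the 4 values shown sit.

The steps joining compound 4 to compound 1 and to compound 3 cannot be read, as both ends of each are limits. The one readable step, with hydroxy in place of dimethylamino, is an at least 13-fold higher number from compound 2 to compound 4 (1.12 log units; beyond the scatter), so dimethylamino remains the only group shown here that gives a measured number, and a group with a hydrogen-bond donor and acceptor does not match it.

From the compounds shown here alone, how hydroxy ranks against methyl or hydrogen stays open, since the true values behind these limits are unknown. Also open, going by these compounds, is whether a primary amine, or dimethylamino on a longer chain, would give a measured number like that of compound 2.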